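From dimethoxyphenyl to naphthyl on an unmeasured core

The source may hold more compounds than are shown below. What is called first, only, known or untested is meant among the compounds shown, and "the series" means these compounds.

In an assay on HL-60 cells for agonist activity at N-formyl peptide receptor 3 (Homo sapiens), read by calcium flux (on this read-out higher numbers stand for an effect only at larger amounts of compound and lower numbers for an effect already at smaller amounts), compound 1 `COc1cccc(Cc2cc(-c3ccccc3)nn(CC(=O)Nc3ccc(F)cc3)c2=O)c1` gives > 50000 nM, which is a limit of the assay and not a number. Compound 2 `COc1cc(Cc2cc(C)nn(CC(=O)Nc3ccc(Br)cc3)c2=O)cc(OC)c1` likewise reaches only a limit in this assay, namely > 50000 nM. Compound 2 therefore stands nowhere on a numerical scale: all that is known is the limit of > 50000 nM in this assay, at which 2 of the 2 values shown sit, and nothing separates compound 2 from compound 1 beyond that shared limit.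

Compound 3 `Cc1cc(Cc2cccc3ccccc23)c(=O)n(CC(=O)Nc2ccc(Br)cc2)n1` has not yet been measured. It differs from compound 2 in one place: naphthalen-1-yl in place of 3,5-dimethoxyphenyl on a saturated chain carbon bound to an aromatic carbon. Within the data shown here, no step between measured compounds is available, so the size of this change cannot be read from any earlier pair. Since compound 2 sits at the limit > 50000 nM, a move into the measurable range would require a change larger than the usual scatter, and the data give no sign of it in either direction. Compound 3 is thus expected to give about 40000 nM in this assay, within a range from 5000 nM to 100000 nM. The step this estimate implies, an at least 1.2-fold lower number from compound 2 to compound 3 (0.09 log units; that floor lies within the scatter), is expected to be none beyond the scatter.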

Compound 3, half-maximal effective concentration: > 50000 nM
Compound 3: only a limit was reported; the forecaster's own chance of this, stated with the estimate: 65%; at least 1.2-fold (0.09 log units) between middle value and limit.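

Compound 2 and compound 3 both stop at a limit in this assay, so the two limits leave no readable step between compound 2 and compound 3. The same holds across the series: the limit of > 50000 nM in this assay, at which 3 of the 3 values shown sit. The compounds shown leave open whether any change to the shared core gives a measurable value in this assay.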